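Shortening the alkynyl chain on the shared nucleoside core

The source may report more compounds than this note shows. Statements on the series, on what has been measured and on what is new or still open speak of the compounds shown alone.

Measured compounds:
compound 1, `CCCCC#Cc1cn([C@H]2C[C@H](O)[C@@H](CO)O2)c(=O)[nH]c1=O`, 1000 ug/mL
compound 2, `COCC#Cc1cn([C@H]2C[C@H](O)[C@@H](CO)O2)c(=O)[nH]c1=O`, 254 ug/mL
compound 3, `O=c1[nH]c(=O)n([C@H]2C[C@H](O)[C@@H](CO)O2)cc1C#CCCCO`, 280 ug/mL

In a functional assay on L1210 cells (Mus musculus) (a higher number here means a weaker inhibitor, a lower number a stronger inhibitor), compound 1 gives 1000 ug/mL, the highest of the three numbers, so it is the weakest inhibitor of the set. The nearest is compound 3, with a 3.6-fold lower number from compound 1 to compound 3 (0.55 log units; beyond the scatter); the furthest is compound 2, with a 3.9-fold lower number from compound 1 to compound 2 (0.60 log units; beyond the scatter). Between compound 2 and compound 3 the step is a 1.1-fold higher number from compound 2 to compound 3 (0.04 log units; within the scatter).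

The step to compound 4, `CCCC#Cc1cn([C@H]2C[C@H](O)[C@@H](CO)O2)c(=O)[nH]c1=O`, is hydrogen in place of methyl on a saturated chain carbon, three bonds along the chain from a triple-bonded carbon. In the same words, the difference cut one bond further out reads butyl to propyl.

Neither measured step is a clean match. The steps from compound 1 to compound 2 and from compound 1 to compound 3 each swap a carbon of the chain for an oxygen-bearing group, and both lowered the number by a modest amount. Shortening the chain by a single carbon, with nothing polar entering, has no direct precedent here. A small drop, not certainly beyond the scatter, is the most that can be expected.

For compound 4 the expected value in this assay is 600 ug/mL, with a range of 250 ug/mL to 1200 ug/mL, which would mean an estimated step of a 1.7-fold lower number from compound 1 to compound 4 (0.22 log units; within the scatter).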

Compound 4, concentration for 50% inhibition: > 1000 ug/mL
Compound 4 ended at the assay's limit (the forecaster's own chance of this, stated with the estimate: 30%); middle value at least 1.6-fold (0.22 log units) away from the limit.
By their numbers in this assay, from the lowest: compounds 2 and 3 (each within the scatter of the next); then compound 1.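

In this assay compound 4 gives > 1000 ug/mL, which is a limit of the assay and not a number. Removing one carbon from the all-carbon chain therefore did not bring the lowering seen with the oxygen-bearing chains; the step is a number no lower from compound 1 to compound 4 (the limit leaves the size open), and it cannot be read, as the result sits at the end of the measured range: the limit of > 1000 ug/mL in this assay, at which 1 of the 4 values shown sits. The two oxygen-bearing chains stay clearly apart from this shorter all-carbon chain, with an at least 3.5-fold higher number from compound 3 to compound 4 (0.55 log units; beyond the scatter) and an at least 3.9-fold higher number from compound 2 to compound 4 (0.59 log units; beyond the scatter), so across these four compounds the lower numbers belong only to chains carrying oxygen, and no compound shown goes against this.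

From the compounds shown here alone, whether going from butyl to propyl changes the number at all remains open, since the limit leaves both its size and its direction undecided beyond "no lower". Also open, going by these compounds, is whether an amine or a carboxylic acid in place of the hydroxy of compound 3 would give a number like those of compound 2 and compound 3, and how a longer chain carrying a hydroxy would compare.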